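One more fluoro on a compound without a number

The compounds below may be only part of what the source reports. "The series", "measured", "known", "first", "only" and "open" are said of these compounds alone.

Three related compounds have been tested so far, and none has yet given a real number. In a functional assay on Bel-7402 cells (Homo sapiens) for inhibition, read by sulforhodamine B assay, with a stated time of 72 h (a higher number here means a weaker inhibitor, a lower number a stronger inhibitor), compound 1 `Cc1ccc2c(c1)c([C@H](C)Nc1ncnc3[nH]cnc13)nn2-c1cccnc1` gives > 40000 nM, which is a limit and not a measured value. Compound 2 `C[C@H](Nc1ncnc2[nH]cnc12)c1nn(-c2cccnc2)c2cc(Cl)ccc12` gives > 40000 nM, again a limit. Compound 3 `C[C@H](Nc1ncnc2[nH]cnc12)c1nn(-c2cccc(F)c2)c2cc(F)ccc12` gives > 40000 nM, also a limit. Compound 3 therefore cannot be ranked against the other two, and the whole picture is the limit of > 40000 nM in this assay, at which 3 of the 3 values shown sit.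

Compound 4 `C[C@H](Nc1ncnc2[nH]cnc12)c1nn(-c2cc(F)cc(F)c2)c2cc(F)ccc12` is compound 3 with a single change: fluoro in place of hydrogen on an aromatic carbon. In words, a fluoro takes the place of a hydrogen on an aromatic carbon, so that 3-fluorophenyl becomes 3,5-difluorophenyl.

Among the compounds with values here, no pair of measured compounds differs in just one place, so no measured step is available as a guide. Within the data shown here, the only basis for a forecast is that every compound tested so far stops at the same limit, and a change this small gives no reason to expect otherwise. No shift beyond the usual scatter is expected in this assay, and the estimated change is a number no higher from compound 3 to compound 4 (the limit leaves the size open). Another limit is the most likely result. For compound 4 the estimated value is 40000 nM, with an expected range from 20000 nM to 80000 nM.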

Compound 4, half-maximal inhibitory concentration: > 40000 nM
Compound 4: no number, only a limit; the forecaster's own chance of this, stated with the estimate: 85%; the middle value lies on the limit itself.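

Compound 3 and compound 4 each give only a limit and not a number, so no step can be read for the change from 3-fluorophenyl to 3,5-difluorophenyl. All the results so far stop at the same point: the limit of > 40000 nM in this assay, at which 4 of the 4 values shown sit. The compounds shown leave open which structure, if any, would give a real number in this assay.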